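The source may report more compounds than this note shows. Statements on the series, on what has been measured and on what is new or still open speak of the compounds shown alone.

Working notes on the series

Compound 1 `Cc1ccccc1NC(=O)N[C@H](C)c1ccccc1` and compound 2 `CCc1ccccc1NC(=O)N[C@H](C)c1ccccc1` share one core. In an ADME assay on the whole organism with Oryza sativa as the target, tested at 1 uM (on this read-out higher numbers stand for a weaker effect at the one concentration tested and lower numbers for a stronger effect), compound 1 gives 100%, and in this assay compound 2 gives 100%. The step of no change at the digits printed from compound 1 to compound 2 (within the scatter) follows from the change (methyl in place of hydrogen on a saturated chain carbon bound to an aromatic carbon). Compound 3 `CCc1cccc(NC(=O)N[C@H](C)c2ccccc2)c1` gives 71% in this assay; its number is the lowest of the three, and it stands apart from compounds 1 and 2 beyond the scatter, so among the measured compounds it shows the strongest effect at the single concentration. How the core of compound 3 differs from the core of compound 1 is not broken down here.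

Compound 4 `CC(C)c1cccc(NC(=O)N[C@H](C)c2ccccc2)c1` is not yet measured in this assay. It differs from compound 3 by methyl in place of hydrogen on a saturated chain carbon bound to an aromatic carbon and a saturated chain carbon. This is the same kind of change as from compound 1 to compound 2, not the same: there the place was a saturated chain carbon bound to an aromatic carbon, here the saturated chain carbon is bound to an aromatic carbon and a saturated chain carbon. The step of a number 1 percentage points higher from compound 3 to compound 4 (within the scatter) is expected to stay within the scatter because no change at the digits printed from compound 1 to compound 2 (within the scatter) showed no change for the earlier methyl for hydrogen exchange. Compound 4 is therefore estimated at 72%, with a range from 55% to 92%.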

Compound 4, a percentage reported as activity, at one concentration (the size of the read-out at that concentration, not a potency): 61%
Estimate against measurement, compound 4: 11 percentage points above; the measured number falls inside the stated range.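

In this assay the exchange of hydrogen for methyl gives a number 10 percentage points lower from compound 3 to compound 4 (within the scatter), so on this core, as on the core of compound 1, the step does not leave the scatter. Set side by side, the two steps do not differ beyond what repeated measurements allow, and the change carries from one core to the other as far as these compounds go: the same change on two cores in this assay, no change at the digits printed (within the scatter) from compound 1 to compound 2 and a number 10 percentage points lower (within the scatter) from compound 3 to compound 4, 10 percentage points apart, within the scatter of two such steps. This rests on two steps only and does not show that the change is neutral on any further core; the place also differs, a saturated chain carbon bound to an aromatic carbon in one step and one bound to an aromatic carbon and a saturated chain carbon in the other, and two steps cannot separate the place from the core.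

On these data alone, it remains open how a longer chain such as n-butyl, an amine or a carboxylic acid would read in the place of the isopropyl group. As far as these compounds go, how the isopropyl group reads on the core of compound 1 also remains open.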